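Macrocyclic pipecolate esters as FKBP4 binders: adding a cyclohexylethyl arm

The source may report more compounds than this note shows. Statements on the series, on what has been measured and on what is new or still open speak of the compounds shown alone.

Compound 1 `CC1(C)COC(=O)CCCCCCCCCCCOC(=O)C2CCCCN2C(=O)C1=O`: 290000 nM
Compound 2 `CC1(C)COC(=O)CCCCCCCCCCCCCCCOC(=O)C2CCCCN2C(=O)C1=O`: 11000000 nM

In an assay on isolated protein for inhibition of peptidyl-prolyl cis-trans isomerase FKBP4 (Homo sapiens) (a lower number here means a stronger inhibitor, a higher number a weaker inhibitor), compound 1 gives 290000 nM, the lower of the two measured numbers, while compound 2 gives 11000000 nM, a gap beyond the usual scatter. Compound 3 `CC1(C)COC(=O)CCCCCCCCCCC(CCC2CCCCC2)OC(=O)C2CCCCN2C(=O)C1=O` is built from compound 1 by the change (2-cyclohexylethyl in place of hydrogen on a saturated ring carbon). Among the measured compounds shown here, no measured pair shows this change, so its effect is not known from data; on the two points available, the step is expected to be a clear gain, a 9.7-fold lower number from compound 1 to compound 3 (0.99 log units; beyond the scatter). Compound 3 is therefore estimated at 30000 nM, with a plausible range from 5000 nM to 200000 nM.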

Compound 3, inhibition constant: 190000 nM
Compound 3: middle estimate off by 6.3-fold (0.80 log units), on the low side; low and high end bracket the measured number.
By their numbers in this assay, from the lowest: compounds 3 and 1 (each within the scatter of the next); then compound 2.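

In this assay, 2-cyclohexylethyl in place of hydrogen on the saturated ring carbon next to the ring oxygen gives a 1.5-fold lower number from compound 1 to compound 3 (0.18 log units; within the scatter), a step that cannot be told apart from repeat-measurement scatter. This carbon therefore carries a large added arm with no measurable loss, and also with no measurable gain. No measurement at hand offers an explanation for this result. Still open, as far as these compounds go, is whether an amine or a carboxylic acid on this same carbon would move the number. Also open, from the compounds shown here alone, is whether the same arm would change the number on the larger ring of compound 2.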